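The source may hold more compounds than are shown below. What is called first, only, known or untested is meant among the compounds shown, and "the series" means these compounds.

Compound 1, `CCCCC1=C(Br)/C(=C/Br)OC1=O`, is one of two compounds tested in a functional assay on Lu1 cells (Homo sapiens) for cytotoxicity; a higher number here means that more compound is needed for the effect, a lower number that less compound is needed. In this assay compound 1 gives only a limit, > 20 ug/mL, not a number. Compound 2, `CCC[C@@H](OC(C)=O)C1=C(Br)[C@@](CI)(OC)OC1=O`, likewise gives in this assay only a limit, > 20 ug/mL. Both values sit at the limit of > 20 ug/mL in this assay, at which 2 of the 2 values shown sit, so compound 1 can be placed no further than that edge. Compound 3, `CCC[C@@H](O)C1=C(Br)/C(=C/Br)OC1=O`, differs from compound 1 by hydroxy in place of hydrogen on a saturated chain carbon bound to a double-bonded ring carbon and a saturated chain carbon. For the measured compounds named here, no measured pair shows what such a change does here. The expected step that the limit leaves unreadable from compound 1 to compound 3 is none beyond the scatter. Compound 3 is expected to give about 30 ug/mL, between 10 ug/mL and 100 ug/mL, most likely again only a limit.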

Compound 3, concentration for half-maximal effect: 0.3 ug/mL
Compound 3: middle estimate off by 100-fold (2.00 log units), on the high side; the measured number lies below the stated range.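

In this assay, hydroxy in place of hydrogen on a saturated chain carbon bound to a double-bonded ring carbon and a saturated chain carbon gives an at least 66-fold lower number from compound 1 to compound 3 (1.82 log units; beyond the scatter). For the compounds shown here, this is the only readable step here, and it shows that a change at this one position can separate a compound that gives only a limit from one with a measured number. The full size of the step stays unknown, as compound 1 rests at the edge of the assay: the limit of > 20 ug/mL in this assay, at which 2 of the 3 values shown sit.

The compounds shown leave open whether a methoxy group or an amine on this carbon would do the same as hydroxy.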